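From methylsulfanyl to methylsulfonyl on the shared core

A few compounds are considered here, and "the series" means these few. Any claim that something is new, unique, unknown or untested is made for them only; others in the source may bear on it.

Compound 2 `CSc1ccc(NC(=O)c2cc3ccccc3oc2=O)cc1` carries a methylsulfanyl group on an aromatic carbon of its outer six-membered ring. In an in vitro assay on BTI-TN-5B1-4 cells for inhibition of Amine oxidase [flavin-containing] B (Homo sapiens), read by fluorescence (a lower number here means a stronger inhibitor, a higher number a weaker inhibitor), compound 2 gives 2840 nM. Within the data shown here, of the two numbers known it is the higher one; its only companion is compound 1 `CC(C)c1ccc(NC(=O)c2cc3ccccc3oc2=O)cc1`, which in this assay gives 650 nM. Among the measured compounds shown here, the single measured step, a 4.4-fold higher number from compound 1 to compound 2 (0.64 log units; beyond the scatter), exchanges one small substituent for another at that aromatic carbon and moves the number upward.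

Compound 3 `CS(=O)(=O)c1ccc(NC(=O)c2cc3ccccc3oc2=O)cc1` is the next candidate. Its change from compound 2 is methylsulfonyl in place of methylsulfanyl on an aromatic carbon. For the measured compounds named here, no measured step exchanges methylsulfanyl for methylsulfonyl, so the only guidance is a 4.4-fold higher number from compound 1 to compound 2 (0.64 log units; beyond the scatter), which shows that a replacement at that aromatic carbon can shift the number beyond the scatter. On that basis a modest further rise is expected rather than a fall, though with wide uncertainty. The step expected for compound 3 is a 1.8-fold higher number from compound 2 to compound 3 (0.25 log units; within the scatter). In this assay compound 3 is estimated at 5000 nM, within a range from 1500 nM to 20000 nM.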

Compound 3, half-maximal inhibitory concentration: 1.4 nM
Beside the measured number, compound 3's estimate is 3600-fold (3.55 log units) above it; measured number outside the range, below it.
By their numbers in this assay, from the lowest: compound 3; then compound 1; then compound 2.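

At this aromatic carbon, para to a large group, methylsulfonyl in place of methylsulfanyl gives a 2000-fold lower number from compound 2 to compound 3 (3.31 log units; beyond the scatter) in this assay, so a position that had so far shown only a 4.4-fold higher number from compound 1 to compound 2 (0.64 log units; beyond the scatter) proves able to carry a far larger change. Sulfur at this carbon does not by itself give the low number, since compound 2 also holds sulfur there and stands highest of the three, while the oxygens on the sulfur of methylsulfonyl mark the one structural difference between that compound and compound 3. The same group also replaces isopropyl with a 460-fold lower number from compound 1 to compound 3 (2.67 log units; beyond the scatter), which places it well ahead of both other substituents on the shared core, and nothing shown gives a reason for the size of either step.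

The compounds shown leave open whether this low number is particular to methylsulfonyl or extends to close relatives such as methylsulfinyl, a sulfonamide or a longer ethylsulfonyl chain, or to unrelated groups such as a nitrile or a carboxylic acid. They also leave open whether methylsulfonyl would give a comparable number at another carbon of that ring.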